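Swapping the aryl group on a shared core

A few compounds are considered here, and "the series" means these few. Any claim that something is new, unique, unknown or untested is made for them only; others in the source may bear on it.

Compound 2 `Clc1ccc(-c2cn3ccnc3c(-c3ccc4ncn(C5CCCCC5)c4c3)n2)cc1` gives 13.1% in a functional assay on EKVX cells (Homo sapiens) for inhibition, read by sulforhodamine B assay, with a stated time of 48 h, tested at 10 uM; a higher number here means more inhibition at the concentration tested (going by the name of the read-out), a lower number less inhibition. Among the compounds with values here, of the two numbers measured so far it is nominally the larger, yet compound 1 `Brc1cn2ccnc2c(-c2ccc3ncn(C4CCCCC4)c3c2)n1`, which gives 12% in this assay, sits within the scatter of it, the step being a number 1.1 percentage points higher from compound 1 to compound 2 (within the scatter). Compound 3 `FC(F)(F)c1cccc(-c2cn3ccnc3c(-c3ccc4ncn(C5CCCCC5)c4c3)n2)c1` has not yet been measured in this assay. It differs from compound 2 in one place: 3-(trifluoromethyl)phenyl in place of 4-chlorophenyl on an aromatic carbon. Within the data shown here, only one measured step bears on that position, a number 1.1 percentage points higher from compound 1 to compound 2 (within the scatter), which puts 4-chlorophenyl in place of bromo and moves the read-out by an amount within the scatter. Among the measured compounds shown here, no measured pair exchanges one substituted phenyl group for another, so the trifluoromethyl variant has no direct precedent here. Given the small size of the one related step, no step beyond the scatter is expected in this assay. Compound 3 is therefore estimated to give 13%, with a range from 3% to 25%. The expected step of a number 0.1 percentage points lower from compound 2 to compound 3 (within the scatter) is a flat one.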

Compound 3, a percentage reported as inhibition, at one concentration (the size of the read-out at that concentration, not a potency): 4.79%
Compound 3: the middle estimate sits 8.2 percentage points above what was measured; the measured number falls inside the stated range.
By their numbers in this assay, from the lowest: compounds 3, 1 and 2 (each within the scatter of the next).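

Within the data shown here, this is the first comparison at this position of one substituted phenyl group with another: in this assay, the exchange of 4-chlorophenyl for 3-(trifluoromethyl)phenyl gives a number 8.3 percentage points lower from compound 2 to compound 3 (within the scatter). Set against the bromo group, the same aryl group gives a number 7.2 percentage points lower from compound 1 to compound 3 (within the scatter), so none of the three exchanges among these groups on this aromatic carbon of the shared core leaves the scatter, even with 3-(trifluoromethyl)phenyl bringing the largest group count of heavy atoms seen here. No measurement is available that would explain the size of either step.

The exchange from compound 2 to compound 3 alters both the substituent on the phenyl ring and its place on that ring, so the compounds shown cannot separate the contribution of trifluoromethyl in place of chlorine from that of the 3-position in place of the 4-position. They also leave open whether an amine or a carboxylic acid on this carbon, or a replacement of the cyclohexyl group elsewhere on the shared core, would produce a step beyond the scatter.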